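A few compounds are considered here, and "the series" means these few. Any claim that something is new, unique, unknown or untested is made for them only; others in the source may bear on it.

Measured so far:
compound 1 `COc1cncc(-c2nnc3ccc(Sc4cc(OC)ccc4OC)nn23)c1`: 440 nM in an assay on HEK293 cells for inhibition of Leucine-rich repeat serine/threonine-protein kinase 2 (Homo sapiens), read by ELISA, with a stated time of 90 min; a lower number here means a stronger inhibitor, a higher number a weaker inhibitor
compound 2 `COc1ccc(OC)c(Sc2ccc3nnc(C4CCN(C)C4)n3n2)c1`: "not determined" (no result reported) in this assay

Compound 2 stands without a number in this assay; only compound 1, which carries a different group on the shared core, gives a value there. Compound 3 `COc1ccc(OC)c(Sc2ccc3nnc(-c4cn(C)nc4C)n3n2)c1` differs from compound 2 by 1,3-dimethyl-1H-pyrazol-4-yl in place of 1-methylpyrrolidin-3-yl on an aromatic carbon. For the measured compounds named here, with no measured step, the size of this change in this assay cannot be read from the data; a step of modest size in either direction, or none beyond the scatter, is expected. Compound 3 is estimated at 500 nM, within 100 nM to 3000 nM. The estimate leans on compound 1, which gives 440 nM in this assay.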

Compound 3, half-maximal inhibitory concentration: 1260 nM
Compound 3: the middle estimate sits 2.5-fold (0.40 log units) below what was measured; the measured number falls inside the stated range.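

In this assay, the aromatic carbon of the shared core now has its first measured step: 1,3-dimethyl-1H-pyrazol-4-yl in place of 5-methoxypyridin-3-yl gives a 2.9-fold higher number from compound 1 to compound 3 (0.46 log units; beyond the scatter), so the choice between these two aromatic rings changes the read-out beyond the scatter, with 5-methoxypyridin-3-yl the stronger of the pair. No measured evidence accounts for this step. Still open, from the compounds shown here alone, is where a non-aromatic group such as 1-methylpyrrolidin-3-yl stands against these two rings, and how a primary amine or a carboxylic acid at this position would read.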